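The source may report more compounds than this note shows. Statements on the series, on what has been measured and on what is new or still open speak of the compounds shown alone.

In a functional assay on G-361 cells (Homo sapiens) for antiproliferative activity, with a stated time of 72 h (on this read-out higher numbers stand for weaker inhibition and lower numbers for stronger inhibition), compound 1 `OC[C@H]1O[C@@H](n2cnc3c(NCc4cccc(F)c4)ncnc32)[C@H](O)[C@@H]1O` gives > 166000 nM, which is a limit of the assay and not a number. Compound 3 `OC[C@H]1O[C@@H](n2cnc3c(NCc4cccc(Br)c4)ncnc32)[C@H](O)[C@@H]1O` gives > 166000 nM, again a limit. Compound 2 `OC[C@H]1O[C@@H](n2cnc3c(NCc4ccccc4Cl)ncnc32)[C@H](O)[C@@H]1O`, the starting point of the step followed here, has no place on this scale, since compound 2 is recorded as "not determined" (no result reported).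

The change leads to compound 4 `OC[C@H]1O[C@@H](n2cnc3c(NCc4ccc(Br)cc4)ncnc32)[C@H](O)[C@@H]1O`, which shares the same core: 4-bromophenyl in place of 2-chlorophenyl on a saturated chain carbon bound to a nitrogen on an aromatic ring. Put simply, 4-bromophenyl stands in place of 2-chlorophenyl on a saturated chain carbon bound to a nitrogen on an aromatic ring, turning 2-chlorobenzyl into 4-bromobenzyl.

Among the measured compounds shown here, only one measured step is available as a guide, a step that the two limits leave unreadable from compound 1 to compound 3, which puts bromo in place of fluoro on an aromatic carbon. It has no readable size. With no value for compound 2, there is also no starting number, so no size or direction can be expected for the step in this assay. What remains is the limit of > 166000 nM in this assay, at which 2 of the 3 values shown sit. The closest guide is compound 3, which also carries a bromo group and gives > 166000 nM, a limit. Compound 4 is therefore expected to show little activity and may well be reported only as a limit. For compound 4 the estimated value is about 150000 nM, with an expected range from 60000 nM to 166000 nM.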

Compound 4, half-maximal inhibitory concentration: > 166000 nM
Compound 4: only a limit was reported; the forecaster's own chance of this, stated with the estimate: 75%; middle value at least 1.1-fold (0.04 log units) away from the limit.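

Compound 4, like compound 1 and compound 3, is reported only as a limit and not as a number, so neither new step, from compound 3 or compound 1 to compound 4, can be read. The compounds shown leave open whether changing these groups alters activity at all in this assay, where the results stop here: the limit of > 166000 nM in this assay, at which 3 of the 4 values shown sit.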